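Acetyl-aryl amides on a shared triazole thioether core

A few compounds are considered here, and "the series" means these few. Any claim that something is new, unique, unknown or untested is made for them only; others in the source may bear on it.

Measured so far:
compound 1 `Cc1occc1-c1nnc(SCC(=O)Nc2ccc(Cl)cc2)n1Cc1ccco1`, 100 nM
compound 2 `CC(=O)c1ccc(NC(=O)CSc2nnc(-c3ccoc3C)n2Cc2ccco2)cc1`, 31.6 nM

For the measured compounds named here, compound 2 gives the lowest number of the two in a functional assay on CHO cells for antagonist activity at Orexin receptor type 2 (Homo sapiens), read by FLIPR and calcium flux; on this read-out higher numbers stand for weaker inhibition and lower numbers for stronger inhibition; compound 1 is its nearest neighbour, and the one measured step, a 3.2-fold lower number from compound 1 to compound 2 (0.50 log units; beyond the scatter), lies beyond the scatter.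

Compound 3 `CC(=O)c1cccc(NC(=O)CSc2nnc(-c3ccoc3C)n2Cc2ccco2)c1` differs from compound 2 by 3-acetylphenyl in place of 4-acetylphenyl on an amide-type nitrogen. Going by the values given here, no measured step touches this change: the only step on hand swaps one group for another at the same place on the aryl ring, and says nothing about moving the acetyl group from 4-acetylphenyl to 3-acetylphenyl. The expectation therefore rests on compound 2 alone, with wide uncertainty in both directions; a modest weakening is taken as the more likely outcome, expected as a 2.0-fold higher number from compound 2 to compound 3 (0.30 log units; within the scatter).

For compound 3 in this assay the estimate is 63 nM, ranging from 20 nM to 320 nM.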

Compound 3, inhibition constant: 316 nM
The estimate for compound 3 lay 5.0-fold (0.70 log units) below the measured number; low and high end bracket the measured number.
By their numbers in this assay, from the lowest: compound 2; then compound 1; then compound 3.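

Where the acetyl group sits on the aryl ring on the amide-type nitrogen matters in this assay: 3-acetylphenyl in place of 4-acetylphenyl, with the same atoms joined differently, gives a 10-fold higher number from compound 2 to compound 3 (1.00 log units; beyond the scatter). The lower number seen with acetyl in the first step therefore does not belong to the acetyl group wherever it sits, since 3-acetylphenyl in place of 4-chlorophenyl gives a 3.2-fold higher number from compound 1 to compound 3 (0.50 log units; beyond the scatter), a change in the opposite direction. Nothing on hand accounts for the difference between the two acetylphenyl groups.

On these data alone, the chloro group appears only as 4-chlorophenyl, so it remains open whether 3-chlorophenyl would move the number in the same direction as the acetyl pair. Also open, as far as these compounds go, is how an amine or a carboxylic acid in place of the acetyl group of 4-acetylphenyl would read.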